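A few compounds are considered here, and "the series" means these few. Any claim that something is new, unique, unknown or untested is made for them only; others in the source may bear on it.

Of the compounds shown here, two have been measured in an assay for inhibition of ribosomal protein S6 kinase beta-1 variant D18H,T412E (Homo sapiens), read by a luciferase reporter and chemiluminescence, with a stated time of 3 h; a lower number here means a stronger inhibitor, a higher number a weaker inhibitor. Compound 1 `Cc1ccc(Cl)cc1N1CCN(c2ncnc(N)c2[N+](=O)[O-])CC1` gives 3 nM. Compound 2 `Cc1ccc(Cl)cc1N1CCN(c2ncnc3[nH]nc(C)c23)CC1`, built on a different core, gives 9 nM in this assay, the higher of the two numbers, and compound 1 stands at a lower number by a margin beyond the scatter. Compound 3 `Cc1ccc(Cl)cc1N1CCN(c2ncnc3[nH]nc(C(C)C)c23)CC1` follows from compound 2 through one change, (isopropyl in place of methyl on an aromatic carbon); the isopropyl enters on the aromatic carbon of the five-membered aromatic ring with two nitrogens that previously held the methyl. Within the data shown here, no step between measured compounds resembles this change, so the expectation rests on compound 2 alone. A small weakening, or no change beyond the scatter, is expected, and the step from compound 2 to compound 3 is therefore estimated at a 1.7-fold higher number from compound 2 to compound 3 (0.22 log units; within the scatter). Compound 3 is expected to give about 15 nM in this assay, within a range from 4 nM to 60 nM.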

Compound 3, half-maximal inhibitory concentration: 16 nM
Compound 3: the middle estimate sits 1.1-fold (0.03 log units) below what was measured, within the range that was stated.
By their numbers in this assay, from the lowest: compound 1; then compounds 2 and 3 (each within the scatter of the next).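

Isopropyl in place of methyl on the aromatic carbon of the five-membered aromatic ring gives a 1.8-fold higher number from compound 2 to compound 3 (0.25 log units; within the scatter) in this assay, the first step read at this position. This carbon therefore carries three heavy atoms in place of one with no difference that can be told from the scatter, so the number in this assay stays in the same range across these two groups. Nothing available bears on why this is so.

The compounds shown leave open how an amine, a carboxylic acid or a longer chain on this carbon would read, as only methyl and isopropyl appear there. On these data alone, it also stays open whether isopropyl would behave in the same way on the core of compound 1 .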